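The compounds below may be only part of what the source reports. "The series", "measured", "known", "first", "only" and "open" are said of these compounds alone.

In a functional assay for inhibition, with Homo sapiens as the target (a higher number here means a weaker inhibitor, a lower number a stronger inhibitor), compound 2 `CN(C)c1ccc(Nc2nccc(-c3cccs3)n2)cc1` gives 900 nM, the second-highest of the three numbers in hand. Compound 1 `CC1CCN(c2ccc(Nc3nccc(-c4cccs4)n3)cc2)CC1` gives 400 nM, and the step of a 2.3-fold higher number from compound 1 to compound 2 (0.35 log units; beyond the scatter) is modest. Compound 3 `c1ccc(Nc2nccc(-c3cccs3)n2)cc1` gives 31700 nM, so the step of a 35-fold higher number from compound 2 to compound 3 (1.55 log units; beyond the scatter) is large. Compound 4 `CN(C)c1ccc(Nc2nccc(-c3ccsc3)n2)cc1` has not been measured. It differs from compound 2 by thiophen-3-yl in place of thiophen-2-yl on an aromatic carbon. Going by the values given here, both measured steps from compound 2 alter the dimethylamino group and leave the thiophen-2-yl untouched, so no measured step bears directly on this change. He therefore expects at most a small step in this assay, likely within the scatter. For compound 4 he estimates 1200 nM, ranging from 400 nM to 3600 nM. This estimate corresponds to an expected step of a 1.3-fold higher number from compound 2 to compound 4 (0.12 log units; within the scatter).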

Compound 4, half-maximal inhibitory concentration: 2100 nM
Compound 4: middle estimate off by 1.8-fold (0.24 log units), on the low side; low and high end bracket the measured number.
By their numbers in this assay, from the lowest: compound 1; then compound 2; then compound 4; then compound 3.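

In this assay, the aromatic carbon next to the ring nitrogen proves sensitive to the point of attachment alone: with the same atoms, thiophen-3-yl in place of thiophen-2-yl gives a 2.3-fold higher number from compound 2 to compound 4 (0.37 log units; beyond the scatter). Going by these compounds alone, the earlier steps changed only the dimethylamino group, so this is the only reading at this position, and the change is modest but real. Nothing measured here explains the difference. As far as these compounds go, it remains open how a furan-2-yl or a phenyl group would fare at this position, and whether thiophen-3-yl costs the same alongside 4-methylpiperidin-1-yl.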